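The source may hold more compounds than are shown below. What is called first, only, known or untested is meant among the compounds shown, and "the series" means these compounds.

Of the compounds shown here, three have been measured in an assay on Sf9 cells for inhibition of protein deacetylase HDAC6 (Homo sapiens), read by fluorescence, with a stated time of 40 min, tested at 100 nM; a higher number here means more inhibition at the concentration tested (going by the name of the read-out), a lower number less inhibition. Compound 2 `Cc1ccc(-c2nc(CNc3ccc(C(=O)NO)cc3)n(-c3ccccc3)n2)cc1` gives 62.2% and stands highest of the three numbers. Compound 1 `CCc1ccc(-n2nc(-c3ccccc3)nc2CNc2ccc(C(=O)NO)cc2)cc1` gives 38.3%, a number that lies beyond the scatter below compound 2. Compound 3 `CNC(=O)c1ccc(NCc2nc(-c3ccccc3)nn2-c2ccccc2)cc1` gives -3.6%, the lowest of the three and again beyond the scatter below compound 2. No pair among these three differs in only one place, so no single-point step has been worked out from them.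

Compound 4 `O=C(NO)c1ccc(NCc2nc(-c3ccc(C(F)(F)F)cc3)nn2-c2ccccc2)cc1` is the next one to be measured in this assay . It differs from compound 2 in one place: trifluoromethyl in place of methyl on an aromatic carbon. For the measured compounds named here, no measured pair shows this kind of change, so its size is open. The expectation is a step from compound 2 to compound 4 of a number 7.2 percentage points lower from compound 2 to compound 4 (within the scatter) in this assay , that is, a small drop that may well stay within the scatter. Compound 4 is accordingly estimated at 55% in this assay , with a range from 30% to 78%.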

Compound 4, a percentage reported as inhibition, at one concentration (the size of the read-out at that concentration, not a potency): 41.6%
Compound 4: the middle estimate sits 13.4 percentage points above what was measured, within the range that was stated.
By their numbers in this assay, from the lowest: compound 3; then compounds 1 and 4 (each within the scatter of the next); then compound 2.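

In this assay, the position para to a large group on this aromatic ring is sensitive to the change: trifluoromethyl in place of methyl gives a number 20.6 percentage points lower from compound 2 to compound 4 (beyond the scatter). For the compounds shown here, this is the first single-place step, so this position can now be read directly, and the earlier compounds offered no such comparison. Inhibition at the concentration tested is reduced but not lost, with compound 4 at 41.6%, and nothing at hand bears on why the number falls.

A single pair cannot separate the effect of the added heavy atoms from that of fluorine itself, so the trend at this position remains undefined. How a methoxy group, an amine or a carboxylic acid at the same place would compare with methyl or trifluoromethyl is open.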